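The source may hold more compounds than are shown below. What is called first, only, known or untested is meant among the compounds shown, and "the series" means these compounds.

Among the compounds with values here, compound 1 `COc1ccc(C(=O)c2ccc3c(ccn3S(=O)(=O)c3ccc(/C=C/C(=O)NO)cc3)c2)cc1` is the first member of the pair measured in an assay on isolated protein for inhibition of polyamine deacetylase HDAC10 (Homo sapiens); on this read-out higher numbers stand for weaker inhibition and lower numbers for stronger inhibition. For compound 1 the assay reports only a limit, > 100000 nM, and no number (the limit of > 100000 nM in this assay, at which 1 of the 2 values shown sits). Within the data shown here, compound 2 `COc1ccc(C(=O)c2ccc3c(ccn3Cc3ccc(C(=O)NO)cc3)c2)cc1OC` gives 18900 nM in this assay, the only numeric value in hand. Compound 3 `O=C(NO)c1ccc(Cn2ccc3cc(C(=O)c4ccc(Cl)cc4)ccc32)cc1` has not been measured; it differs from compound 2 by 4-chlorophenyl in place of 3,4-dimethoxyphenyl on a carbonyl carbon. Among the measured compounds shown here, no step between measured compounds is available for this change, so the step of a 1.1-fold higher number from compound 2 to compound 3 (0.02 log units; within the scatter) is expected to stay within the usual scatter, in no clear direction. Compound 3 is estimated at 20000 nM, in the range 5000 nM to 80000 nM.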

Compound 3, half-maximal inhibitory concentration: > 100000 nM
Compound 3: no number, only a limit (the forecaster's own chance of this, stated with the estimate: 15%); middle value at least 5.0-fold (0.69 log units) from the limit.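

On a carbonyl carbon, the aryl group is not interchangeable in this assay: 4-chlorophenyl in place of 3,4-dimethoxyphenyl gives an at least 5.2-fold higher number from compound 2 to compound 3 (0.72 log units; beyond the scatter). Within the data shown here, this is the first reading of any change at this position. Compound 3 gives a limit and not a number, so the true size of the step stays unknown, and the series already sits largely at that limit: the limit of > 100000 nM in this assay, at which 2 of the 3 values shown sit.

Still open, from the compounds shown here alone, is whether the step follows from the departure of the two methoxy groups or the arrival of the chlorine. A 4-methoxyphenyl or an unsubstituted phenyl on the same carbonyl carbon would separate the two.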